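The source may report more compounds than this note shows. Statements on the series, on what has been measured and on what is new or still open speak of the compounds shown alone.

Of the compounds shown here, three have been measured in a functional assay for inhibition of sodium- and chloride-dependent glycine transporter 1 (Rattus norvegicus), with a stated time of 30 min, in the presence of a further agent that is not named here; on this read-out lower numbers stand for stronger inhibition and higher numbers for weaker inhibition. Compound 1 `NC(C/C=C(\c1ccsc1)c1ccc(F)cc1F)C(=O)O` returns only a limit in this assay, giving > 10000 nM. Among the compounds with values here, compound 3 `NC(C/C=C(/c1ccc(-c2ccccc2)cc1)c1ccc(F)cc1F)C(=O)O` is the one member for which a number rather than a limit has been obtained, and in this assay compound 3 gives 3400 nM.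

Compound 2 `COc1ccc(/C(=C/CC(N)C(=O)O)c2ccc(C(C)C)cc2)cc1` likewise reaches only a limit, and in this assay compound 2 gives > 10000 nM. Compound 2 therefore stands at the limit of this assay the limit of > 10000 nM in this assay, at which 2 of the 3 values shown sit, together with compound 1, and its value cannot be set in order against either of the other two.

Compound 4 `CC(C)c1ccc(/C(=C\CC(N)C(=O)O)c2ccccc2)cc1` is compound 2 with a hydrogen in place of methoxy on an aromatic carbon; cut one bond further out, the same difference reads 4-methoxyphenyl to phenyl. Within the data shown here, no measured pair differs in just this way, so there is no measured step to lean on. Since compound 2 sits at a limit, the step to compound 4 in this assay cannot be sized in either direction; the expectation is that compound 4 also stays weak, and the estimated step is a step that the limit leaves unreadable from compound 2 to compound 4. Compound 4 is estimated at 15000 nM, within a range of 5000 nM to 50000 nM.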

Compound 4, half-maximal inhibitory concentration: 8340 nM
Beside the measured number, compound 4's estimate is 1.8-fold (0.25 log units) above it; the measured number falls inside the stated range.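

Hydrogen in place of methoxy on an aromatic carbon, para to a large group, gives an at least 1.1-fold lower number from compound 2 to compound 4 (0.07 log units; that floor lies within the scatter) in this assay. This shows what compound 2 alone could not: with the methoxy gone, the compound gives a readable number, so the methoxy at this position is not needed for measurable inhibition on this scaffold, and compound 4 gives 8340 nM. The true size of the change cannot be read, though, and neither its size nor a real gain can be claimed, since compound 2 holds only a limit and not a number: the limit of > 10000 nM in this assay, at which 2 of the 4 values shown sit.

The compounds shown leave open how large the change from 4-methoxyphenyl to phenyl is when it starts from a number rather than from a limit, and whether it would run the same way on another member of the series. They also leave open how a different group on this same aromatic carbon, such as a chlorine atom, a hydroxyl group or an amine, would compare with the hydrogen of compound 4.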